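Sulfonate series: cyclopentylmethyl urea in place of chloropropyl urea

The source may report more compounds than this note shows. Statements on the series, on what has been measured and on what is new or still open speak of the compounds shown alone.

Of the compounds shown here, two carry numbers so far. Compound 1 `CC(C)(C)C(=O)Nc1ccc(S(=O)(=O)Oc2ccccc2I)cc1` gives 8300 nM in a functional assay on M21 cells (Homo sapiens) for antiproliferative activity, read by sulforhodamine B assay, with a stated time of 48 h; on this read-out higher numbers stand for weaker inhibition and lower numbers for stronger inhibition. Compound 2 `O=C(NCCCCl)Nc1ccc(S(=O)(=O)Oc2ccccc2I)cc1` gives 4600 nM in this assay. Among the compounds with values here, the one step between them, a 1.8-fold lower number from compound 1 to compound 2 (0.26 log units; within the scatter), is within the scatter, so the two sit together and neither can be set apart from the other on these data.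

Compound 3 `O=C(NCC1CCCC1)Nc1ccc(S(=O)(=O)Oc2ccccc2I)cc1` is not yet measured. It differs from compound 2 in one place: cyclopentyl in place of 2-chloroethyl on a saturated chain carbon bound to an amide-type nitrogen. Within the data shown here, no measured step touches the chain on the urea nitrogen in this way; the only step known, a 1.8-fold lower number from compound 1 to compound 2 (0.26 log units; within the scatter), exchanges the whole urea side for a tert-butyl amide and itself stays within the scatter. There is therefore no measured ground for a shift in either direction in this assay, and the expectation is a step no larger than the scatter.

On that basis the number for compound 3 in this assay is estimated at 4500 nM, within a range of 1500 nM to 13000 nM. This estimate means a step of a 1.0-fold lower number from compound 2 to compound 3 (0.01 log units; within the scatter) and is expected to hold only loosely, given that the series supplies no comparable change.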

Compound 3, half-maximal inhibitory concentration: 7600 nM
Compound 3: the middle estimate sits 1.7-fold (0.23 log units) below what was measured; the measured number falls inside the stated range.
By their numbers in this assay, from the lowest: compounds 2, 3 and 1 (each within the scatter of the next).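

In this assay, the exchange of cyclopentyl in place of 2-chloroethyl on a saturated chain carbon bound to an amide-type nitrogen gives a 1.7-fold higher number from compound 2 to compound 3 (0.22 log units; within the scatter) and so shows that this place accepts a five-membered ring of carbon only, without a step that can be told from the scatter. The exchange of (cyclopentylmethyl)amino in place of tert-butyl on a carbonyl carbon gives a 1.1-fold lower number from compound 1 to compound 3 (0.04 log units; within the scatter) and so places all three compounds together, with neither the chlorine nor the ring setting any of them apart on these numbers. No evidence bearing on either step is available.

Still open, on these data alone, is whether a group of another kind at this place, such as a terminal amine, a carboxylic acid or a longer chain, would give a step beyond the scatter. The rest of the core is the same in all three compounds, so what its parts contribute cannot be read from these numbers.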